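Reshaping the Diamine Ring of Compound 2

This account rests on a few compounds, and the source may have more. Where it says the series, first, only, none or still open, it means among the compounds named here.

Compound 1 `Cc1ccc(Nc2ncc(Cl)c(Nc3ccccc3C)n2)cc1`: > 100000 nM (a limit)
Compound 2 `CCN1CCN(c2ccc(Nc3ncc(Cl)c(Nc4ccccc4C)n3)cc2)CC1`: 3040 nM
Compound 3 `Cc1ccccc1Nc1nc(Nc2ccc(N3CCN(C(=O)OC(C)(C)C)CC3)cc2)ncc1Cl`: 3260 nM

In a functional assay on MDA-MB-231 cells (Homo sapiens) for inhibition, read by CCK-8 assay, with a stated time of 48 h (a higher number here means a weaker inhibitor of growth, a lower number a stronger inhibitor of growth), compound 2 gives 3040 nM, level with compound 3 at 3260 nM. Compound 1 has no true number, only a limit of the assay. Compound 2 therefore shares the best-defined readings with compound 3, and neither stands apart from the other.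

Compound 4 `Cc1ccccc1Nc1nc(Nc2ccc(N3CCCN(C)CC3)cc2)ncc1Cl` is built from the same atoms as compound 2, joined differently: 4-methyl-1,4-diazepan-1-yl in place of 4-ethylpiperazin-1-yl on an aromatic carbon. A six-membered ring becomes a seven-membered one, and ethyl gives way to methyl.

Going by the values given here, two measured steps bear on this. The large step, an at least 32-fold lower number from compound 1 to compound 2 (1.51 log units; beyond the scatter), shows that the group at this place can matter greatly, but it compares that ring with a plain methyl. The closer guide is a 1.1-fold higher number from compound 2 to compound 3 (0.03 log units; within the scatter), where a much bigger change on the ring nitrogen left the reading within the scatter. A step beyond the scatter is therefore not expected, in either direction. The estimate means a 1.1-fold lower number from compound 2 to compound 4 (0.04 log units; within the scatter), an expected step of small size. For compound 4 the estimated value is 2800 nM, with an expected range of 1000 nM to 8000 nM.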

Compound 4, concentration for 50% growth inhibition: 6390 nM
The estimate for compound 4 lay 2.3-fold (0.36 log units) below the measured number, within the range that was stated.
By their numbers in this assay, from the lowest: compounds 2, 3 and 4 (each within the scatter of the next, the first and the last beyond it). At a limit, above all of these: compound 1.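

Replacing the six-membered ring and its ethyl group with the seven-membered ring and its methyl group, using the same atoms, gives a 2.1-fold higher number from compound 2 to compound 4 (0.32 log units; beyond the scatter), a modest step that shows the shape of the diamine ring can shift the reading even though the large change on the ring nitrogen in compound 3 did not. The seven-membered ring still stands far from the plain methyl group, with an at least 15-fold lower number from compound 1 to compound 4 (1.19 log units; beyond the scatter). That step has only a lower bound, because compound 1 stands at a limit of the assay: the limit of > 100000 nM in this assay, at which 1 of the 4 values shown sits.

Ring size and the ethyl-to-methyl change arrive together here, and a piperazine ring carrying methyl would help to tell them apart. Also open, from the compounds shown here alone, is how a morpholine ring or an open-chain dimethylamino group would read at this place.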